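The source may hold more compounds than are shown below. What is called first, only, known or untested is meant among the compounds shown, and "the series" means these compounds.

- compound 1 `C=C1C=CC(=O)[C@@H]2[C@H](Cc3ccc(F)c(F)c3)CC[C@H]12` gives 428 nM
- compound 2 `C=C1C=CC(=O)[C@@H]2[C@H](Cc3ccc(OC)c(F)c3)CC[C@H]12` gives 2.45 nM
- compound 3 `C=C1C=CC(=O)[C@@H]2[C@H](Cc3ccc(O)cc3)CC[C@H]12` gives 218 nM

These three values come from a functional assay on COLO 205 cells (Homo sapiens) for antiproliferative activity, with a stated time of 72 h; on this read-out lower numbers stand for stronger inhibition and higher numbers for weaker inhibition. Among them, compound 3 at 218 nM sits within the scatter of compound 1 at 428 nM, and both numbers lie far above that of compound 2 at 2.45 nM.

The next compound to be tested is compound 4 `C=C1C=CC(=O)[C@@H]2[C@H](Cc3ccc(O)c(F)c3)CC[C@H]12`, which differs from compound 3 by fluoro in place of hydrogen on an aromatic carbon, ortho to a hydroxy group and meta to a large group: fluoro in place of hydrogen on an aromatic carbon.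

Within the data shown here, no measured step makes this change directly. Among the measured compounds shown here, the only step available, a 170-fold lower number from compound 1 to compound 2 (2.24 log units; beyond the scatter), is large, but it is methoxy in place of fluoro, so it replaces a different group and gives no direct measure of adding fluoro. It does show that two compounds carrying this same fluoro can lie far apart, so the new fluoro alone fixes little. Only a small shift is therefore expected in this assay, leaning towards a lower number and probably not beyond the scatter. The estimated step is a 1.8-fold lower number from compound 3 to compound 4 (0.26 log units; within the scatter). For compound 4 the expected value is 120 nM, with an estimated range from 25 nM to 500 nM.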

Compound 4, half-maximal inhibitory concentration: 3000 nM
Estimate against measurement, compound 4: 25-fold (1.40 log units) below, outside the stated range (above it).
By their numbers in this assay, from the lowest: compound 2; then compounds 3 and 1 (each within the scatter of the next); then compound 4.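

In this assay, fluoro in place of hydrogen on an aromatic carbon, ortho to a hydroxy group and meta to a large group, is a large change and not a silent one: a 14-fold higher number from compound 3 to compound 4 (1.14 log units; beyond the scatter). With that fluoro held in place, the group on the oxygen matters greatly, as hydrogen in place of methyl on an oxygen on an aromatic ring gives the largest step in the set, a 1200-fold higher number from compound 2 to compound 4 (3.09 log units; beyond the scatter). Hydroxy in place of fluoro on the same aromatic carbon gives a modest step, a 7.0-fold higher number from compound 1 to compound 4 (0.85 log units; beyond the scatter), so of the three compounds carrying this fluoro, compound 4 has the highest number and compound 2 the lowest, and an oxygen at this carbon does not by itself bring a low number.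

No data here on the compounds offer an explanation for why the added fluoro raises the number alongside a hydroxy group. From the compounds shown here alone, it remains open how the same change would read alongside methoxy, and whether chloro in place of this fluoro, or an amine in place of the hydroxy group, would fall nearer compound 2 or compound 4.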